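A few compounds are considered here, and "the series" means these few. Any claim that something is new, unique, unknown or untested is made for them only; others in the source may bear on it.

Of the compounds shown here, three sharing one core have been measured in a functional assay on CAKI-1 cells (Homo sapiens) for cytotoxicity, read by sulforhodamine B assay, with a stated time of 48 h; a higher number here means a weaker inhibitor of growth, a lower number a stronger inhibitor of growth. Compound 1 `ClCc1ccccc1Cn1cnc2c(Cl)nc(Cl)nc21` gives 890 nM. Compound 2 `ClCc1ccccc1Cn1cnc2c(Cl)ncnc21` gives 4170 nM, and compound 3 `ClCc1ccccc1Cn1cnc2ncnc(Cl)c21` gives 4160 nM. Compound 2 therefore shows the highest number of the three; its number and that of compound 3 lie within the scatter of each other, whereas the step of a 4.7-fold higher number from compound 1 to compound 2 (0.67 log units; beyond the scatter) reaches beyond it, so compound 1 is the stronger growth inhibitor of that pair.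

Compound 4 `Nc1nc(Cl)c2ncn(Cc3ccccc3CCl)c2n1` has not yet been measured. It differs from compound 2 by amino in place of hydrogen on an aromatic carbon, the new group sitting between two ring nitrogen atoms. Among the compounds with values here, no measured step exchanges hydrogen for an amino group; the only step known, a 4.7-fold higher number from compound 1 to compound 2 (0.67 log units; beyond the scatter), removes a chloro group, which is a different kind of change and gives only a loose guide. Under this uncertainty the step of a 1.4-fold lower number from compound 2 to compound 4 (0.14 log units; within the scatter) is expected to stay within or close to the scatter. Compound 4 is accordingly estimated at 3000 nM, with a range from 800 nM to 12000 nM.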

Compound 4, concentration for total growth inhibition: 20400 nM
Estimate against measurement, compound 4: 6.8-fold (0.83 log units) below; measured number above the stated range.
By their numbers in this assay, from the lowest: compound 1; then compounds 3 and 2 (each within the scatter of the next); then compound 4.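

In this assay the position between two ring nitrogen atoms now carries three different groups on the shared core, and amino in place of hydrogen gives a 4.9-fold higher number from compound 2 to compound 4 (0.69 log units; beyond the scatter) while amino in place of chloro gives a 23-fold higher number from compound 1 to compound 4 (1.36 log units; beyond the scatter) on the same position. Together with the earlier step, this puts the numbers in the order chloro, then hydrogen, then amino, so a group here can move growth inhibition in either direction from hydrogen, not only strengthen it. Nothing shown gives a measured reason for this order.

On these data alone, three groups make a short series, so it remains open where a methyl, a methoxy or a bromo group at this position would fall. A dimethylamino group would also test whether the change seen with amino persists once its hydrogens are replaced.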